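The source may report more compounds than this note shows. Statements on the series, on what has been measured and on what is new or still open speak of the compounds shown alone.

Measured so far, in a functional assay on HT-29 cells (Homo sapiens) for cytotoxicity, read by MTT assay, with a stated time of 72 h; a higher number here means that more compound is tolerated, a lower number that less compound is tolerated:
Compound 1, `[SeH]c1nc(NCc2ccccc2)c2cccnc2n1`: > 100000 nM, a limit of the assay rather than a number.
Compound 2, `CCCCC[Se]c1nc(NCc2ccccc2)c2ccccc2n1`: > 100000 nM, again a limit of the assay.
Compound 3, `CSc1nc(NCCCCc2ccccc2)c2ccccc2n1`: > 100000 nM, also a limit of the assay.

Compound 3 therefore stands exactly where the other two stand. Of its value only a limit is known, and the same holds for the two further values shown. Among the measured compounds shown here, the one piece of evidence in these numbers is the limit of > 100000 nM in this assay, at which 3 of the 3 values shown sit; since every value rests at that same boundary, nothing about order or relative strength can be read from them, and no compound may be called more or less tolerated than another. For the measured compounds named here, no two measured compounds differ in a single place, so no step has been measured.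

Compound 4, `CSc1nc(NCCCCCO)c2ccccc2n1`, differs from compound 3 in one place: hydroxymethyl in place of phenyl on a saturated chain carbon, four bonds along the chain from a nitrogen on an aromatic ring. In words, this is hydroxymethyl in place of phenyl on a saturated chain carbon, four bonds along the chain from a nitrogen on an aromatic ring; cut one bond further out, the same difference reads benzyl to 2-hydroxyethyl.

With no measured step and every shown value at the limit, the expected change in this assay is none beyond the scatter: a number no higher from compound 3 to compound 4 (the limit leaves the size open). Compound 4 is accordingly estimated at 100000 nM, within a range from 30000 nM to 300000 nM, with a good chance that the assay once more reports only its limit.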

Compound 4, concentration lethal to 50% of the cells: > 100000 nM
Compound 4: a limit, no number; the forecaster's own chance of this, stated with the estimate: 85%; the middle value sits exactly at the limit.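

The step from compound 3 to compound 4, hydroxymethyl in place of phenyl, cannot be read, as both results are limits of the assay and not numbers. The compounds shown leave open the actual lethal concentration of each one, and whether any change in structure alters it, with every result resting at one boundary: the limit of > 100000 nM in this assay, at which 4 of the 4 values shown sit.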